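Bromine Substitution on a Sulfonamide-Bearing Hybrid Scaffold

The compounds below may be only part of what the source reports. "The series", "measured", "known", "first", "only" and "open" are said of these compounds alone.

Compound 3 `NS(=O)(=O)c1cccc(/N=C2\NC(=O)/C(=C3/C(=O)Nc4ccccc43)S2)c1` was examined in a functional assay on MCF7 cells (Homo sapiens) for antiproliferative activity, read by MTT assay; on this read-out lower numbers stand for stronger inhibition and higher numbers for weaker inhibition. In that setting compound 3 gives > 200000 nM, which is a limit of the assay and not a number. Its position among the measured compounds is therefore at the edge of what the assay can report, a place it shares with another member of the set, as shown by the limit of > 200000 nM in this assay, at which 2 of the 3 values shown sit. Compound 1 `CN1C(=O)/C(=C2\S/C(=N/c3ccc(S(N)(=O)=O)cc3)NC2=O)c2cc(Cl)ccc21` gives > 200000 nM in this assay, likewise a limit. Compound 2 `NS(=O)(=O)c1ccc(/N=C2\NC(=O)/C(=C3/C(=O)Nc4ccc(Br)cc43)S2)cc1`, which also carries a bromine, gives 11300 nM in this assay.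

Compound 4 `NS(=O)(=O)c1cccc(/N=C2\NC(=O)/C(=C3/C(=O)Nc4ccc(Br)cc43)S2)c1` is related to compound 3 by a single change: bromo in place of hydrogen on an aromatic carbon. Among the compounds with values here, no measured pair isolates this change, so its effect in this assay cannot be read from the data; the only anchor is compound 2, whose value of 11300 nM shows that a bromine-bearing analogue can register a number. Starting from a limit, compound 4 is expected to move by an at least 2.5-fold lower number from compound 3 to compound 4 (0.39 log units; beyond the scatter) toward measurable activity, with a real chance that the assay again reports only a limit. The estimate for compound 4 is 80000 nM, within a range from 10000 nM to 300000 nM.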

Compound 4, half-maximal inhibitory concentration: > 200000 nM
Compound 4 ended at the assay's limit (the forecaster's own chance of this, stated with the estimate: 50%); middle value at least 2.5-fold (0.39 log units) from the limit.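

Compound 3 and compound 4 both stand at a limit of this assay and not at a number, so no step between them can be read: the limit of > 200000 nM in this assay, at which 3 of the 4 values shown sit.

The compounds shown leave open whether bromo in place of hydrogen on an aromatic carbon changes the read-out at all in this assay.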